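Removing a Chlorine from the Amide Pyridine

The compounds below may be only part of what the source reports. "The series", "measured", "known", "first", "only" and "open" are said of these compounds alone.

Three compounds share one core and differ only in the aromatic group attached to the amide carbonyl. Compound 1 `O=C(Nc1ccc(Cl)c(-c2nnc3c(Cl)cccn23)c1)c1cccc(Cl)c1` carries a 3-chlorophenyl group, and in a functional assay on MDA-MB-231 cells (Homo sapiens) for antiproliferative activity, read by MTT assay, with stated times of 72 h and 4 h (a lower number here means a stronger inhibitor, a higher number a weaker inhibitor), compound 1 gives 66100 nM. Compound 2 `O=C(Nc1ccc(Cl)c(-c2nnc3c(Cl)cccn23)c1)c1ccccn1` carries a pyridin-2-yl group, and in this assay compound 2 gives 92000 nM. Compound 3 `O=C(Nc1ccc(Cl)c(-c2nnc3c(Cl)cccn23)c1)c1cccnc1Cl` carries a 2-chloropyridin-3-yl group, and in this assay compound 3 gives 89700 nM, the second highest of the three numbers, with compound 2 the nearest and compound 1 the furthest.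

The step to compound 4 `O=C(Nc1ccc(Cl)c(-c2nnc3c(Cl)cccn23)c1)c1cccnc1` is hydrogen in place of chloro on an aromatic carbon. For the measured compounds named here, no measured pair shows exactly this change. The closest guide is that every swap among the three measured amide groups stayed within the scatter: a 1.4-fold higher number from compound 1 to compound 2 (0.14 log units; within the scatter), a 1.4-fold higher number from compound 1 to compound 3 (0.13 log units; within the scatter) and a 1.0-fold lower number from compound 2 to compound 3 (0.01 log units; within the scatter). Since these three quite different groups gave numbers in this assay that sit within the scatter of one another, removing one chloro from the six-membered aromatic ring with one nitrogen is expected to leave the number about where it stands, with no step beyond the scatter. Compound 4 is therefore estimated at 85000 nM, within a range of 40000 nM to 180000 nM, which is expected to mean a 1.1-fold lower number from compound 3 to compound 4 (0.02 log units; within the scatter).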

Compound 4, half-maximal inhibitory concentration: > 100000 nM
Compound 4: no number, only a limit; the forecaster's own chance of this, stated with the estimate: 15%; middle value at least 1.1-fold (0.07 log units) from the limit.
By their numbers in this assay, from the lowest: compounds 1, 3 and 2 (each within the scatter of the next). At a limit, above all of these: compound 4.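

In this assay, compound 4 gives a limit of the assay and not a number: the limit of > 100000 nM in this assay, at which 1 of the 4 values shown sits. Hydrogen in place of chloro, on the aromatic carbon next to the ring nitrogen, gives an at least 1.1-fold higher number from compound 3 to compound 4 (0.04 log units; that floor lies within the scatter), and the pyridin-3-yl group compared with the other two amide groups gives an at least 1.0-fold higher number from compound 2 to compound 4 (0.03 log units; that floor lies within the scatter) and an at least 1.5-fold higher number from compound 1 to compound 4 (0.17 log units; that floor lies within the scatter). From the compounds shown here alone, what is new is that this position can take the series out of the range the assay reports, yet all three steps are only floors that lie within the scatter, so they do not establish a real change and the true size of each step stays unknown.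

The compounds shown leave open whether any replacement for the chloro on this pyridine, such as an amine, a methoxy group or a methyl group, would bring the number down. They also leave open whether an amide group of another kind, such as one carrying a carboxylic acid or a longer chain, would move the number beyond the scatter at all.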